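The compounds below may be only part of what the source reports. "The series", "measured", "known", "first", "only" and "open" are said of these compounds alone.

Measured compounds in an ADME assay on Huh7.5.1 cells (Homo sapiens) for cytotoxicity, read by ATP content, with a stated time of 48 h; a higher number here means that more compound is tolerated, a lower number that less compound is tolerated:
compound 1, `Cc1oc(-c2ccc(Cl)cc2)nc1CN1CCC(C(=O)NCCCN2C[C@H](C)C[C@H](C)C2)CC1`: compound 1 gives 11500 nM
compound 2, `Cc1ccccc1-c1nc(CN2CCC(C(=O)N3CCN(CCN(C)C)CC3)CC2)c(C)o1`: compound 2 gives 27200 nM

Of the two compounds measured, compound 1 stands lowest in this assay; its nearest neighbour, compound 2, gives a number beyond the scatter above it, so less of compound 1 is tolerated than of compound 2. Within the data shown here, no pair of measured compounds that differ in only one place is available, so no measured step can be drawn on. Compound 3, `COc1cccc(F)c1-c1nc(CN2CCC(C(=O)NCCCN3C[C@H](C)C[C@H](C)C3)CC2)c(C)o1`, differs from compound 1 in one place: 2-fluoro-6-methoxyphenyl in place of 4-chlorophenyl on an aromatic carbon. Among the measured compounds shown here, nothing among the measured compounds shows what this kind of change does in this assay. The step of a 1.2-fold higher number from compound 1 to compound 3 (0.09 log units; within the scatter) is therefore expected to be small, within the scatter, with only a slight lean toward a higher number. Compound 3 is estimated at 14000 nM, with a range from 6000 nM to 35000 nM.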

Compound 3, half-maximal cytotoxic concentration: 37000 nM
Estimate against measurement, compound 3: 2.6-fold (0.42 log units) below; the whole stated range lies below it.
By their numbers in this assay, from the lowest: compound 1; then compounds 2 and 3 (each within the scatter of the next).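

In this assay, among these compounds, the change to 2-fluoro-6-methoxyphenyl in place of 4-chlorophenyl gives a 3.2-fold higher number from compound 1 to compound 3 (0.51 log units; beyond the scatter) and is the only measured step at this position. It shows that the group on this aromatic carbon can alter the number beyond the scatter while the rest of compound 1 stays the same, and here the change goes toward more compound being tolerated. The entering group is larger by two heavy atoms and brings one hydrogen-bond acceptor, but no measurement given here ties the step to either feature or to any cause.

The compounds shown leave open whether the fluorine, the methoxy group or the loss of the chlorine carries the step. They also leave open where a plain phenyl or a pyridine would fall at this position.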